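Swapping the pyridine of compound 3 for a trimethylpyrazole

This account rests on a few compounds, and the source may have more. Where it says the series, first, only, none or still open, it means among the compounds named here.

Measured compounds:
compound 1 `CN(Cc1ccc2nccn2c1)c1nnc(-c2ccc(-c3ccccc3F)cc2)o1` 4.4
compound 2 `Cc1ccccc1-c1ccc(-c2nnc(N(C)Cc3ccc4nccn4c3)o2)cc1` 4.7
compound 3 `Cc1ncccc1-c1ccc(-c2nnc(N(C)Cc3ccc4nccn4c3)o2)cc1` 3.1

In a physicochemical assay for lipophilicity, at pH 7.4 (on this read-out higher numbers stand for higher lipophilicity and lower numbers for lower lipophilicity), compound 3 stands lowest of the three measured compounds. Compound 4 `Cc1nn(C)c(C)c1-c1ccc(-c2nnc(N(C)Cc3ccc4nccn4c3)o2)cc1` differs from it by 1,3,5-trimethyl-1H-pyrazol-4-yl in place of 2-methylpyridin-3-yl on an aromatic carbon. For the measured compounds named here, no measured step involves a pyrazole, so the nearest guides are the two steps that placed the pyridine: a number 1.30 log units lower from compound 1 to compound 3 (beyond the scatter) and a number 1.60 log units lower from compound 2 to compound 3 (beyond the scatter), both large falls. The incoming group again carries ring nitrogens, now two, together with three methyls, so a number close to that of compound 3 is expected, with a number 0.10 log units lower from compound 3 to compound 4 (within the scatter) as the estimated step, not beyond the scatter. Compound 4 is therefore estimated at 3, within a range of 2.3 to 3.7.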

Compound 4, distribution coefficient: 3.1
Estimate against measurement, compound 4: 0.10 log units below; low and high end bracket the measured number.
By their numbers in this assay, from the lowest: compounds 3 and 4 (each within the scatter of the next); then compounds 1 and 2 (each within the scatter of the next).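

In this assay there is no change at the digits printed from compound 3 to compound 4 (within the scatter) when 1,3,5-trimethyl-1H-pyrazol-4-yl replaces 2-methylpyridin-3-yl, so at this position a five-membered aromatic ring with 2 hetero atoms reads the same as a six-membered one with 1 hetero atom. With a number 1.60 log units lower from compound 2 to compound 4 (beyond the scatter) and a number 1.30 log units lower from compound 1 to compound 4 (beyond the scatter) alongside, the large fall from the substituted phenyl rings is no longer tied to the pyridine alone. Nothing available explains why the two rings match.

Still open, on these data alone, is whether a pyrazole without its methyls would read the same. Also open, as far as these compounds go, is how a ring carrying an amine or a carboxylic acid would behave here.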